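This account rests on a few compounds, and the source may have more. Where it says the series, first, only, none or still open, it means among the compounds named here.

Measured in an ADME assay on HepG2 2.2.15 cells (Homo sapiens) for cytotoxicity; on this read-out higher numbers stand for lower toxicity in this test and lower numbers for higher toxicity in this test:

Compound 1 `CCC(=O)OCCc1c(-c2ccccc2Cl)c2cc(Cl)ccc2[nH]c1=O` gives 95000 nM
Compound 2 `CC(=O)NCC(=O)OCCc1c(-c2ccccc2Cl)c2cc(Cl)ccc2[nH]c1=O` gives 110000 nM
Compound 3 `COc1ccccc1/C=C/C(=O)OCCc1c(-c2ccccc2Cl)c2cc(Cl)ccc2[nH]c1=O` gives 770000 nM

Compound 3, at 770000 nM, holds the highest number of the three, and its steps to both others lie beyond the scatter. Compound 4 `C/C=C/C(=O)OCCc1c(-c2ccccc2Cl)c2cc(Cl)ccc2[nH]c1=O` has not yet been measured. It differs from compound 3 by methyl in place of 2-methoxyphenyl on a double-bonded chain carbon bound to a double-bonded chain carbon.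

Among the measured compounds shown here, three measured steps bear on this change. Bringing in the 2-(2-methoxyphenyl)ethenyl group gave a modest step beyond the scatter in both available cases: an 8.1-fold higher number from compound 1 to compound 3 (0.91 log units; beyond the scatter), and a 7.0-fold higher number from compound 2 to compound 3 (0.85 log units; beyond the scatter). The two compounds without that group sit together: a 1.2-fold higher number from compound 1 to compound 2 (0.06 log units; within the scatter). For the measured compounds named here, compound 4 gives up the 2-methoxyphenyl but keeps the double bond, and no measured compound shows that double bond without the ring, so part of the higher number might remain. A return towards the level of compound 1 and compound 2 is still what the data suggest. The expected step is a 5.9-fold lower number from compound 3 to compound 4 (0.77 log units; beyond the scatter), towards lower numbers and beyond the scatter. For compound 4 the estimated value is 130000 nM, with an expected range from 55000 nM to 400000 nM.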

Compound 4, half-maximal cytotoxic concentration: 30000 nM
For compound 4 the middle estimate is 4.3-fold (0.64 log units) above the measured one, outside the stated range (below it).
By their numbers in this assay, from the lowest: compound 4; then compounds 1 and 2 (each within the scatter of the next); then compound 3.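

In this assay, among the compounds shown here, the double bond alone does not keep the higher number of compound 3: methyl in place of 2-methoxyphenyl on a double-bonded chain carbon bound to a double-bonded chain carbon gives a 26-fold lower number from compound 3 to compound 4 (1.41 log units; beyond the scatter) and so removes more than the earlier steps had added. Compound 4 also fails to return to the level of the two saturated esters, since prop-1-en-1-yl gives a 3.7-fold lower number from compound 2 to compound 4 (0.56 log units; beyond the scatter) in place of acetamidomethyl on a carbonyl carbon and a 3.2-fold lower number from compound 1 to compound 4 (0.50 log units; beyond the scatter) in place of ethyl at that same place. The double bond and the ring had come in together in compound 3, so only compound 4 separates them, and nothing at hand gives a reason for the drop.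

The compounds shown leave open whether the whole aromatic ring or its methoxy group goes with the higher number, which a plain phenyl on the double-bonded chain carbon would address. They also leave open whether the double bond is needed once the ring is present, as a saturated 2-(2-methoxyphenyl)ethyl group on the carbonyl carbon would show.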